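The source may hold more compounds than are shown below. What is called first, only, known or untested is meant among the compounds shown, and "the series" means these compounds.

Compound 1: `C[C@@H]1O[C@H](n2cc(COP(=O)(O)OP(=O)(O)OC[C@H]3O[C@@H](n4cnc5c(=O)[nH]c(N)nc54)[C@H](O)[C@@H]3O)nn2)[C@@H](O)[C@H](O)[C@@H]1O` — 137000 nM in an assay on isolated protein for inhibition of 4-galactosyl-N-acetylglucosaminide 3-alpha-L-fucosyltransferase 9 (Homo sapiens), read by scintillation counting, with a stated time of 30 min; a lower number here means a stronger inhibitor, a higher number a weaker inhibitor.
Compound 2: `C[C@H]1O[C@@H](n2cc(COP(=O)(O)OP(=O)(O)OC[C@H]3O[C@@H](n4cnc5c(=O)[nH]c(N)nc54)[C@H](O)[C@@H]3O)nn2)[C@H](O)[C@@H](O)[C@H]1O` — 190000 nM in this assay.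

Compound 2 gives the highest of the two numbers, with compound 1 the nearest, a 1.4-fold higher number from compound 1 to compound 2 (0.14 log units; within the scatter). That single step concerns only drawn configuration the fact that one of compounds 1 and 2 is drawn with a defined configuration and the other without, at the place where they differ and does not touch the change now at hand. Compound 3, `Nc1nc2c(ncn2[C@@H]2O[C@H](COP(=O)(O)OP(=O)(O)OCc3cn([C@@H]4O[C@H](CO)[C@H](O)[C@H](O)[C@H]4O)nn3)[C@@H](O)[C@H]2O)c(=O)[nH]1`, differs from compound 2 by hydroxy in place of hydrogen on a saturated chain carbon bound to a saturated ring carbon. For the measured compounds named here, no measured step bears on adding a hydroxy here, so no direction beyond the scatter is expected; the estimated step is a 1.3-fold higher number from compound 2 to compound 3 (0.12 log units; within the scatter). For compound 3 the expected value in this assay is 250000 nM, within 100000 nM to 700000 nM.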

Compound 3, inhibition constant: 186000 nM
For compound 3 the middle estimate is 1.3-fold (0.13 log units) above the measured one; the range from low to high includes it.
By their numbers in this assay, from the lowest: compounds 1, 3 and 2 (each within the scatter of the next).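

In this assay, hydroxy in place of hydrogen on a saturated chain carbon bound to a saturated ring carbon gives a 1.0-fold lower number from compound 2 to compound 3 (0.01 log units; within the scatter), so methyl to hydroxymethyl does not separate these two compounds. The larger change in the group on the aromatic nitrogen gives a 1.4-fold higher number from compound 1 to compound 3 (0.13 log units; within the scatter), which leaves all three compounds within the scatter of one another. Nothing available here bears on why this change leaves the number where it is. From the compounds shown here alone, whether an amine, a carboxylic acid or a longer chain on that saturated chain carbon would move the number beyond the scatter remains open.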